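Removing a Methyl from Compound 2

A few compounds are considered here, and "the series" means these few. Any claim that something is new, unique, unknown or untested is made for them only; others in the source may bear on it.

Measured compounds:
compound 1, `Cc1ccc(-c2nc3ccc(Br)cn3c2/C=N/OCc2cn(Cc3ccc([N+](=O)[O-])cc3)nn2)cc1`: 20 mg/kg
compound 2, `Cc1ccc(-c2nc3ccc(Br)cn3c2/C=N/OCc2cn(Cc3ccc(C#N)cc3)nn2)cc1`: 40 mg/kg
compound 3, `Cc1ccc(Cn2cc(CO/N=C/c3c(-c4ccc(C)cc4)nc4ccc(Br)cn34)nn2)cc1`: 100 mg/kg

These numbers come from a functional assay on the whole organism (strain NMRI) with Mus musculus as the target, with a stated time of 4 h; a higher number here means that more compound is needed for the effect, a lower number that less compound is needed. Compound 2 holds the second highest of the three values. Its nearest neighbour is compound 1, with a 2.0-fold higher number from compound 1 to compound 2 (0.30 log units; within the scatter); compound 3 lies further off, with a 2.5-fold higher number from compound 2 to compound 3 (0.40 log units; beyond the scatter).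

Compound 4, `N#Cc1ccc(Cn2cc(CO/N=C/c3c(-c4ccccc4)nc4ccc(Br)cn34)nn2)cc1`, differs from compound 2 in one place: hydrogen in place of methyl on an aromatic carbon.

Among the compounds with values here, the measured steps of a 2.0-fold higher number from compound 1 to compound 2 (0.30 log units; within the scatter), a 5.0-fold higher number from compound 1 to compound 3 (0.70 log units; beyond the scatter) and a 2.5-fold higher number from compound 2 to compound 3 (0.40 log units; beyond the scatter) all exchange the group on the benzyl ring; none changes the 4-methylphenyl group, so no measured step bears directly on this change. Without such evidence, the step from compound 2 to compound 4 is expected to be no change at the digits printed from compound 2 to compound 4 (within the scatter), nothing beyond the scatter. Compound 4 is therefore estimated at 40 mg/kg, within 20 mg/kg to 100 mg/kg.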

Compound 4, minimum effective dose: 20 mg/kg
The estimate for compound 4 lay 2.0-fold (0.30 log units) above the measured number, within the range that was stated.
By their numbers in this assay, from the lowest: compounds 1, 4 and 2 (each within the scatter of the next); then compound 3.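

In this assay, within the data shown here, the first step at this position, from 4-methylphenyl to phenyl, gives a 2.0-fold lower number from compound 2 to compound 4 (0.30 log units; within the scatter). The methyl can therefore be removed without a change beyond the usual scatter, at least in this compound with its nitrile-bearing benzyl group. Nothing available explains this result.

From the compounds shown here alone, whether the methyl can also be removed without such a change when the benzyl ring carries the nitro group of compound 1 remains open. So does the outcome of placing a larger group here, such as an amine or a carboxylic acid.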